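Swapping a dimethylaminophenyl for pyridin-4-yl on an amide

The compounds below may be only part of what the source reports. "The series", "measured", "known", "first", "only" and "open" are said of these compounds alone.

Measured so far:
compound 1, `CN(C)c1cccc(C(=O)N[C@H]2CCC[C@H](NC(=O)c3cccc(Cl)c3)C2)c1`, > 10000 nM
compound 2, `O=C(N[C@@H]1CCC[C@H](NC(=O)c2ccccn2)C1)c1cccc(Cl)c1`, 1510 nM

The measured pair are compound 1 and compound 2. In a functional assay on HEK293 cells for antagonist activity at metabotropic glutamate receptor 5 (Homo sapiens), read by FLIPR and calcium flux (on this read-out higher numbers stand for weaker inhibition and lower numbers for stronger inhibition), compound 1 gives only a limit, > 10000 nM, and no number. In this assay compound 2 gives 1510 nM. Compound 1 thus stands at the limit of > 10000 nM in this assay, at which 1 of the 2 values shown sits, so its true value is not pinned down.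

The unmeasured compound 3, `O=C(N[C@H]1CCC[C@H](NC(=O)c2cccc(Cl)c2)C1)c1ccncc1`, differs from compound 1 in one place: pyridin-4-yl in place of 3-(dimethylamino)phenyl on a carbonyl carbon.

Going by the values given here, no step between measured compounds is available, so the expectation rests on the two values alone. Compound 3 is expected to move toward stronger inhibition by an at least 2.0-fold lower number from compound 1 to compound 3 (0.30 log units; that floor lies within the scatter) in this assay, a step likely beyond the scatter, though with a fair chance that only a limit is reported again. Compound 3 is estimated at 5000 nM, within 1500 nM to 15000 nM, in this assay.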

Compound 3, half-maximal inhibitory concentration: 300 nM
Compound 3: the middle estimate sits 17-fold (1.22 log units) above what was measured, and the stated range ends above it.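

In this assay, the group on this carbonyl carbon proves to matter a great deal: pyridin-4-yl in place of 3-(dimethylamino)phenyl gives an at least 33-fold lower number from compound 1 to compound 3 (1.52 log units; beyond the scatter), the first step shown at this place in the molecule. The two groups have the same counts of hydrogen-bond donors and acceptors, so the step comes with no change in those counts, while the group shrinks from 9 heavy atoms to 6. Compound 1 gives only a limit, so the step is a floor and its full size remains unknown because of that limit: the limit of > 10000 nM in this assay, at which 1 of the 3 values shown sits.

The compounds shown leave open whether the step goes with the ring nitrogen of pyridin-4-yl or with the loss of the dimethylamino group. An unsubstituted phenyl or a pyridin-3-yl on the same carbonyl carbon would tell these two readings apart.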